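Replacing naphthalen-1-yl with 2-methoxyphenyl on an amide-type nitrogen

The compounds below may be only part of what the source reports. "The series", "measured", "known", "first", "only" and "open" are said of these compounds alone.

- compound 1 `NC(=O)c1c(NC(=O)c2ccccc2Cl)sc2c1CCN(Cc1ccccc1Cl)C2` with 27500 nM
- compound 2 `NC(=O)c1c(NC(=O)c2ccccc2Cl)sc2c1CCN(C(=S)Nc1cccc3ccccc13)C2` with 30800 nM

Among the measured compounds shown here, in a functional assay on HeLa cells (Homo sapiens) for antiproliferative activity, with a stated time of 24 h (a higher number here means a weaker inhibitor, a lower number a stronger inhibitor), compound 2 gives 30800 nM and so stands within the scatter of compound 1 at 27500 nM on the numbers so far. The next compound to be tested is compound 3 `COc1ccccc1NC(=S)N1CCc2c(sc(NC(=O)c3ccccc3Cl)c2C(N)=O)C1` and its difference from compound 2 is 2-methoxyphenyl in place of naphthalen-1-yl on an amide-type nitrogen with 2-methoxyphenyl in place of naphthalen-1-yl on an amide-type nitrogen. For the measured compounds named here, no measured pair differs in only one place, so no measured step can guide this change. The expectation therefore starts from compound 2 at 30800 nM and assumes no shift beyond the scatter, in either direction. The estimated 1.1-fold lower number from compound 2 to compound 3 (0.06 log units; within the scatter) is accordingly small. For compound 3 the expected value is 27000 nM in an estimated range of 11000 nM to 65000 nM for this measurement.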

Compound 3, half-maximal inhibitory concentration: > 50000 nM
Compound 3: a limit, no number (the forecaster's own chance of this, stated with the estimate: 15%); middle value at least 1.8-fold (0.26 log units) away from the limit.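

In this assay, compound 3 gives a limit and not a number: the limit of > 50000 nM in this assay, at which 1 of the 3 values shown sits.

At this amide-type nitrogen, putting 2-methoxyphenyl in place of naphthalen-1-yl gives an at least 1.6-fold higher number from compound 2 to compound 3 (0.21 log units; that floor lies within the scatter), so the position does not gain strength from this change, though the floor alone does not establish a real loss. The exchange of the whole group on the amine nitrogen in the ring gives an at least 1.8-fold higher number from compound 1 to compound 3 (0.25 log units; that floor lies within the scatter), and this too shows only a floor, with no measured size for the step.

As far as these compounds go, how far the true value of compound 3 lies past its limit remains open, and with it the real size of both steps. Also open, from the compounds shown here alone, is how an unsubstituted phenyl or a 2-naphthyl group would behave on this nitrogen, and whether the methoxy group or the loss of the second aromatic ring matters more.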